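Methoxy to Hydroxy on a Lactone Core

A few compounds are considered here, and "the series" means these few. Any claim that something is new, unique, unknown or untested is made for them only; others in the source may bear on it.

Compound 1 `C=C1C(=O)O[C@H](C2=C(C)C(O)CC2=O)[C@@H]1CCC(C)=O` gives 3% in a functional assay on HaCaT cells (Homo sapiens) for cytotoxicity, read by ELISA and LDH release, with a stated time of 6 h, tested at 10 ug/mL; on this read-out higher numbers stand for a weaker effect at the one concentration tested and lower numbers for a stronger effect.
Compound 2 `C=C1C(=O)O[C@H](C2=C(C)[C@@H](OC)CC2=O)[C@@H]1CCC(C)=O` gives 7% in this assay.

The two numbers sit within the scatter of each other, so compound 2 is not distinguishable from compound 1 on this read-out. Compound 3 `C=C1C(=O)O[C@H](C2=C(C)[C@@H](O)CC2=O)[C@@H]1CCC(C)=O` differs from compound 2 by hydrogen in place of methyl on an oxygen on a saturated carbon. Within the data shown here, no measured pair shows this change, so nothing beyond the two values themselves guides the expectation. Given that compound 1 and compound 2 are within the scatter of each other, the expected step of a number 2 percentage points lower from compound 2 to compound 3 (within the scatter) is none beyond the scatter. Compound 3 is therefore expected to give 5%, between 0% and 15%.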

Compound 3, a percentage reported as activity, at one concentration (the size of the read-out at that concentration, not a potency): 18%
The estimate for compound 3 lay 13 percentage points below the measured number, and the stated range ends below it.
By their numbers in this assay, from the lowest: compounds 1 and 2 (each within the scatter of the next); then compound 3.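

Replacing methoxy with hydroxy on this saturated ring carbon gives a number 11 percentage points higher from compound 2 to compound 3 (beyond the scatter) in this assay, so at this position the change shows up as a weaker effect at the one concentration tested. The same atoms and bonds also give a number 15 percentage points higher from compound 1 to compound 3 (beyond the scatter), and the one thing that separates that pair is this: the fact that one of compounds 1 and 3 is drawn with a defined configuration and the other without, at the place where they differ

The configuration at that carbon in compound 1 stays undefined, so the result cannot be assigned to a particular stereoisomer. Going by these compounds, whether an ethoxy group or an acetate ester on this oxygen would follow methoxy or hydroxy also remains open.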